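From Phenol to Cyclopentyl Ether in a DDX3X Series

The source may hold more compounds than are shown below. What is called first, only, known or untested is meant among the compounds shown, and "the series" means these compounds.

Measured compounds:
Compound 1 `CCCCc1cn(-c2ccc(NC(=O)Nc3cc(CCC(C)=O)ccc3C)cc2)nn1` gives 2490 nM in an assay on isolated protein for inhibition of ATP-dependent RNA helicase DDX3X (Homo sapiens), read by FRET, with stated times of 30 s and 40 min; on this read-out higher numbers stand for weaker inhibition and lower numbers for stronger inhibition.
Compound 2 `CCCCc1cn(-c2ccc(NC(=O)Nc3cc(OC4CCOC4)ccc3C)cc2)nn1` gives 100 nM in this assay.
Compound 3 `CCCCc1cn(-c2ccc(NC(=O)Nc3cc(O)ccc3C)cc2)nn1` gives 490 nM in this assay.

Compound 3 stands second highest of the three numbers: it sits a 4.9-fold higher number from compound 2 to compound 3 (0.69 log units; beyond the scatter), while a 5.1-fold lower number from compound 1 to compound 3 (0.71 log units; beyond the scatter).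

Compound 4 `CCCCc1cn(-c2ccc(NC(=O)Nc3cc(OC4CCCC4)ccc3C)cc2)nn1` differs from compound 3 in one place: cyclopentyl in place of hydrogen on an oxygen on an aromatic ring.

Going by the values given here, the step that bears most directly on this change is the one from compound 2 to compound 3, where the oxolan-3-yl group on the ring oxygen was replaced by hydrogen and gave a 4.9-fold higher number from compound 2 to compound 3 (0.69 log units; beyond the scatter). Compound 4 reverses this kind of step, putting a five-membered carbon ring of the same ring size onto the same oxygen. The wider comparison from compound 1 also shows that both oxygen-linked groups outperform the 2-acetylethyl chain, as a 25-fold lower number from compound 1 to compound 2 (1.40 log units; beyond the scatter) and a 5.1-fold lower number from compound 1 to compound 3 (0.71 log units; beyond the scatter) show. A step in this assay of about the size seen from compound 2 to compound 3, in the direction of a lower number, is therefore expected, though the missing ring oxygen leaves the match imperfect.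

For compound 4 the expected number in this assay is 130 nM, with a range from 50 nM to 400 nM, which is expected to be a 3.8-fold lower number from compound 3 to compound 4 (0.58 log units; beyond the scatter).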

Compound 4, half-maximal inhibitory concentration: 140 nM
Compound 4: the middle estimate sits 1.1-fold (0.03 log units) below what was measured; low and high end bracket the measured number.
By their numbers in this assay, from the lowest: compounds 2 and 4 (each within the scatter of the next); then compound 3; then compound 1.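

In this assay, cyclopentyl on the oxygen gives a 3.5-fold lower number from compound 3 to compound 4 (0.54 log units; beyond the scatter), and cyclopentyloxy in place of 2-acetylethyl gives an 18-fold lower number from compound 1 to compound 4 (1.25 log units; beyond the scatter), so the lower number no longer rests on oxolan-3-yl alone but also appears with a ring of carbon only. Exchanging the two rings gives a 1.4-fold higher number from compound 2 to compound 4 (0.15 log units; within the scatter), which lies within the scatter, so the ring oxygen of oxolan-3-yl makes no readable difference to the number at this position. No measurement is available here that accounts for these steps.

Going by these compounds, it remains open whether the result extends to a smaller or larger carbon ring, such as cyclobutyl or cyclohexyl, or to an open chain, such as isopropyl, on the same oxygen. It is also unclear how a ring carrying an amine, such as pyrrolidinyl, or a group ending in a carboxylic acid would compare with compound 2 and compound 4 at this position.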